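Methoxy at a Shared Position on Two Quinoxaline-Type Sulfones

The source may hold more compounds than are shown below. What is called first, only, known or untested is meant among the compounds shown, and "the series" means these compounds.

Of the compounds shown here, three built on one shared core have been measured in a functional assay on HCT-116 cells (Homo sapiens) for cytotoxicity, read by MTT assay, with a stated time of 72 h; a higher number here means a weaker inhibitor, a lower number a stronger inhibitor. Compound 1 `Nc1ccc(Nc2nc3ccccc3nc2S(=O)(=O)c2ccccc2)cc1` gives 10800 nM, and compound 2 `COc1ccc(S(=O)(=O)c2nc3ccccc3nc2Nc2ccc(N)cc2)cc1` gives 6300 nM. Compound 2 differs from compound 1 by methoxy in place of hydrogen on an aromatic carbon, and this change gave a 1.7-fold lower number from compound 1 to compound 2 (0.23 log units; within the scatter). Compound 3 `O=S(=O)(c1ccc(Br)cc1)c1nc2ccccc2nc1Nc1ccccc1` carries a different set of substituents on the same core; the difference between the two cores is not broken down here. In this assay compound 3 gives 1110 nM, the lowest number of the three and beyond the scatter from both others, so it is the strongest inhibitor measured so far.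

Compound 4 `COc1ccc(Nc2nc3ccccc3nc2S(=O)(=O)c2ccc(Br)cc2)cc1` has not yet been measured. It differs from compound 3 by methoxy in place of hydrogen on an aromatic carbon, the same change as that from compound 1 to compound 2. Since that earlier step lay within the scatter, the step from compound 3 to compound 4 is expected to be about as small, estimated as a 1.4-fold lower number from compound 3 to compound 4 (0.14 log units; within the scatter). Compound 4 is therefore estimated to give 800 nM in this assay, expected to fall between 350 nM and 1800 nM.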

Compound 4, half-maximal inhibitory concentration: 3400 nM
Compound 4: middle estimate off by 4.3-fold (0.63 log units), on the low side, outside the stated range (above it).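

In this assay, the change from anilino to (4-methoxyphenyl)amino gave a 3.1-fold higher number from compound 3 to compound 4 (0.49 log units; beyond the scatter), so compound 4 stands on the weaker side of compound 3. Set beside the earlier step, methoxy in place of hydrogen did not carry over from one core to the other with the same result: the same change on two cores in this assay, a 1.7-fold lower number (0.23 log units; within the scatter) from compound 1 to compound 2 and a 3.1-fold higher number (0.49 log units; beyond the scatter) from compound 3 to compound 4, 5.3-fold (0.72 log units) apart, beyond the scatter of two such steps This shows that, for these two pairs, the result of the change on one core was no guide to its direction or size on the other, but two steps give no rule for the series and do not show which of the differences between the cores lies behind the gap.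

The compounds shown leave open whether a hydroxyl, an ethoxy group, a longer chain or a carboxylic acid in the place of the methoxy would give a number nearer that of compound 3 or that of compound 4. They also leave open how methoxy in place of hydrogen would read on a third core, so neither step can be called the more typical one.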